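Trading a Pentyloxy Chain for Benzyloxy

This account rests on a few compounds, and the source may have more. Where it says the series, first, only, none or still open, it means among the compounds named here.

In a functional assay on RAW264.7 cells (Mus musculus) for inhibition, read by Griess assay, with stated times of 1 h and 24 h (a lower number here means a stronger inhibitor, a higher number a weaker inhibitor), compound 1 `CC(C)COc1ccccc1C1CC(=O)c2ccccc2O1` reads 36700 nM and compound 2 `CCCCCOc1ccccc1C1CC(=O)c2ccccc2O1` reads 39200 nM on the same test. These two numbers lie within the scatter of each other, so compound 2 cannot be separated from compound 1 on what has been measured. Compound 3 `O=C1CC(c2ccccc2OCc2ccccc2)Oc2ccccc21` has no reading yet. Its difference from compound 2 is phenyl in place of butyl on a saturated chain carbon bound to an oxygen on an aromatic ring which means phenyl in place of butyl on a saturated chain carbon bound to an oxygen on an aromatic ring. Within the data shown here, the only measured step that bears on this is a 1.1-fold higher number from compound 1 to compound 2 (0.03 log units; within the scatter) and it swapped one chain for another at that same place. Among the measured compounds shown here, no measured compound has a ring entering there, so this guide is weak. The expected size of the change, a 1.1-fold lower number from compound 2 to compound 3 (0.05 log units; within the scatter) in this assay stays within the scatter, with no clear direction. Compound 3 is estimated at 35000 nM with an expected range from 14000 nM to 80000 nM on this reading.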

Compound 3, half-maximal inhibitory concentration: 18900 nM
Beside the measured number, compound 3's estimate is 1.9-fold (0.27 log units) above it, and the stated range covers the measured number.
By their numbers in this assay, from the lowest: compounds 3, 1 and 2 (each within the scatter of the next, the first and the last beyond it).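

In this assay, this saturated chain carbon bound to an oxygen on an aromatic ring gives its first step beyond the scatter once a ring enters: a 2.1-fold lower number from compound 2 to compound 3 (0.32 log units; beyond the scatter). Chain-for-chain exchange had shown no such separation, so trading pentyloxy for benzyloxy is the first change here that can be told apart from noise, though only modestly. The comparison with the other chain is weaker, at a 1.9-fold lower number from compound 1 to compound 3 (0.29 log units; within the scatter), and compound 3 cannot be separated from compound 1.

From the compounds shown here alone, whether an aromatic ring is needed at this place stays open, and a cyclohexyl group in place of the phenyl, or an amine on the phenyl ring, would test how far the trend extends. No supporting measurement is available to explain the step from butyl to phenyl.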